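The source may report more compounds than this note shows. Statements on the series, on what has been measured and on what is new or still open speak of the compounds shown alone.

Among the measured compounds shown here, in a functional assay on MKN-28 cells (Homo sapiens) for inhibition, read by sulforhodamine B assay, with a stated time of 48 h (on this read-out higher numbers stand for weaker inhibition of growth and lower numbers for stronger inhibition of growth), compound 1 (`CCCCCCCCCCCC[C@@H](O)[C@H]1CC[C@H]([C@H](O)CCCCCCCCCCNC(=O)c2ccnn2C)O1`) gives 10 nM, the lower of the two numbers so far, while compound 2 (`CCCCCCCCCCCC[C@@H](O)[C@H]1CC[C@H]([C@H](O)CCCCCCCCCCN(C)C(=O)c2ccnn2C)O1`) gives 302 nM. Compound 3 (`CCCCCCCCCCCC[C@@H](O)[C@H]1CC[C@H]([C@H](O)CCCCCCCCCCOC(=O)c2ccnn2C)O1`) is still unmeasured and keeps the core of compound 1, with one change in the side chain: ((1-methyl-1H-pyrazol-5-yl)carbonyl)oxy in place of ((1-methyl-1H-pyrazol-5-yl)carbonyl)amino on a saturated chain carbon, ten or more bonds along the chain from an oxygen on a saturated carbon and a saturated ring carbon. The amide hydrogen is lost in this change. For the measured compounds named here, only one measured step also loses it: a 30-fold higher number from compound 1 to compound 2 (1.48 log units; beyond the scatter), with methyl in place of hydrogen on an amide-type nitrogen. That step is an imperfect guide, since it adds a methyl and leaves the amide nitrogen in place, and the series holds no measured ester. A weaker result is therefore expected, with a somewhat smaller shift, estimated as an 8.0-fold higher number from compound 1 to compound 3 (0.90 log units; beyond the scatter) in this assay. For compound 3 the estimated value is 80 nM, with an expected range from 15 nM to 400 nM.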

Compound 3, concentration for 50% growth inhibition: 2510 nM
Beside the measured number, compound 3's estimate is 31-fold (1.50 log units) below it; the measured number lies above the stated range.
By their numbers in this assay, from the lowest: compound 1; then compound 2; then compound 3.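

Replacing the amide nitrogen with oxygen costs more than methylating it in this assay: the change gives a 250-fold higher number from compound 1 to compound 3 (2.40 log units; beyond the scatter), and the ester also falls short of the methylated amide, with an 8.3-fold higher number from compound 2 to compound 3 (0.92 log units; beyond the scatter) in the same assay. Compound 2 and compound 3 both lack the amide hydrogen yet remain clearly apart, so the absence of that hydrogen does not alone set the level at this place on the chain, and the identity of the linking atom also matters. Nothing measured here gives a reason for this difference.

Open, from the compounds shown here alone, is whether a urea or a sulfonamide in this place would stay near compound 1 or fall toward compound 3. Also open, going by these compounds, is whether a phenyl ring in place of the 1-methyl-1H-pyrazol-5-yl group would keep the same order among amide, methylated amide and ester.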